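The source may report more compounds than this note shows. Statements on the series, on what has been measured and on what is new or still open speak of the compounds shown alone.

In a functional assay on EBC-1 cells (Homo sapiens) for antiproliferative activity, read by sulforhodamine B assay, with a stated time of 72 h (a higher number here means a weaker inhibitor, a lower number a stronger inhibitor), the measured compounds stand as follows:
compound 1 `Cn1cc(-c2ccc(=O)n(CCOc3ccnc4cc(OCCCC(=O)NO)ccc34)n2)cn1` gives 870 nM
compound 2 `Cn1cc(-c2ccc(=O)n(CCOc3ccnc4cc(OCCCCCC(=O)NO)ccc34)n2)cn1` gives 460 nM
compound 3 `CC(=O)CCCCCOc1ccc2c(OCCn3nc(-c4cnn(C)c4)ccc3=O)ccnc2c1` gives 25 nM

Of these three, compound 3 has the lowest number and is the strongest inhibitor. Compound 4 `Cn1cc(-c2ccc(=O)n(CCOc3ccnc4cc(C(=O)Nc5ccccc5N)ccc34)n2)cn1` departs from it on an aromatic carbon of the shared core, where (2-aminophenyl)carbamoyl stands in place of (5-acetylpentyl)oxy ((2-aminophenyl)carbamoyl in place of (5-acetylpentyl)oxy on an aromatic carbon). Among the measured compounds shown here, no measured step makes this exchange, so the evidence is indirect. The step between the two hydroxycarbamoyl compounds, a 1.9-fold lower number from compound 1 to compound 2 (0.28 log units; within the scatter), lies within the scatter. Exchanging the chain end gave large steps, a 35-fold lower number from compound 1 to compound 3 (1.54 log units; beyond the scatter) and an 18-fold lower number from compound 2 to compound 3 (1.26 log units; beyond the scatter), so the number in these compounds does respond to that part of the molecule. As compound 3 already sits lowest and loses its whole chain here, a sizeable rise in this assay is expected, though with wide uncertainty. The estimate is a 6.0-fold higher number from compound 3 to compound 4 (0.78 log units; beyond the scatter), a rise of similar order to those large steps. For compound 4 the expected value is 150 nM, with an estimated range from 30 nM to 800 nM in this assay.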

Compound 4, half-maximal inhibitory concentration: > 10000 nM
Compound 4 ended at the assay's limit; the forecaster's own chance of this, stated with the estimate: 5%; middle value at least 66-fold (1.82 log units) from the limit.
By their numbers in this assay, from the lowest: compound 3; then compounds 2 and 1 (each within the scatter of the next). At a limit, above all of these: compound 4.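

In this assay compound 4 stands at a limit of the assay and not at a number: the limit of > 10000 nM in this assay, at which 1 of the 4 values shown sits. The earlier compounds shown here differed only in the chain on this aromatic carbon, and all gave measured values, whereas (2-aminophenyl)carbamoyl in place of the whole chain brings an at least 400-fold higher number from compound 3 to compound 4 (2.60 log units; beyond the scatter), along with an at least 21-fold higher number from compound 2 to compound 4 (1.33 log units; beyond the scatter) and an at least 11-fold higher number from compound 1 to compound 4 (1.06 log units; beyond the scatter). This position therefore responds to more than the chain end, and the step from the strongest compound exceeds the largest one seen among the chains, a 35-fold lower number from compound 1 to compound 3 (1.54 log units; beyond the scatter).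

The compounds shown leave open whether the rise follows from losing the chain or from the (2-aminophenyl)carbamoyl itself, since neither a short methoxy on this carbon nor a (2-aminophenyl)carbamoyl at the end of a chain appears among them. On these data alone, how far compound 4 lies beyond its limit also stays open.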